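A Pyridyl Switch on an Inactive Benzyl Analogue

This account rests on a few compounds, and the source may have more. Where it says the series, first, only, none or still open, it means among the compounds named here.

Compound 1 `COc1ccc(-n2nc(Nc3cc(C)[nH]n3)c3ccccc3c2=O)cc1` and compound 2 `COc1ccc(Cn2nc(Nc3cc(C)[nH]n3)c3ccccc3c2=O)cc1` share one core and differ only at an aromatic nitrogen. In a functional assay on MCF7 cells (Homo sapiens) for cytotoxicity (on this read-out higher numbers stand for weaker inhibition and lower numbers for stronger inhibition), compound 1 gives 3600 nM. For compound 2 this assay reports > 30000 nM, which is a limit of the assay rather than a number. The step of an at least 8.3-fold higher number from compound 1 to compound 2 (0.92 log units; beyond the scatter) rests on the limit of > 30000 nM in this assay, at which 1 of the 2 values shown sits, and places compound 2 as the weaker of the two. Compound 3 `Cc1cc(Nc2nn(Cc3cccnc3)c(=O)c3ccccc23)n[nH]1`, not yet measured, differs from compound 2 by pyridin-3-yl in place of 4-methoxyphenyl on a saturated chain carbon bound to an aromatic nitrogen. Within the data shown here, no measured step exchanges one aromatic ring for another on that chain carbon, so nothing among the measured compounds speaks directly to this change. The account therefore expects no step beyond the scatter a step that the limit leaves unreadable from compound 2 to compound 3, with compound 3 likely to sit again at the limit. Compound 3 is estimated at 40000 nM, within a range from 10000 nM to 150000 nM.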

Compound 3, half-maximal inhibitory concentration: 13400 nM
The estimate for compound 3 lay 3.0-fold (0.47 log units) above the measured number, within the range that was stated.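

On the saturated chain carbon bound to an aromatic nitrogen, the choice of ring can move the read-out in this assay, with an at least 2.2-fold lower number from compound 2 to compound 3 (0.35 log units; beyond the scatter). How large that step really is stays unreadable, for compound 2 carries a limit of the assay and not a number: the limit of > 30000 nM in this assay, at which 1 of the 3 values shown sits. Even so, (pyridin-3-yl)methyl does not bring the series back to the level of the directly attached 4-methoxyphenyl, with a 3.7-fold higher number from compound 1 to compound 3 (0.57 log units; beyond the scatter).

The compounds shown leave open whether the change follows the ring nitrogen of pyridin-3-yl or the departure of the methoxy group, a question that an unsubstituted benzyl on the same aromatic nitrogen would address. They also leave open whether pyridin-3-yl bound directly to that nitrogen would match or pass compound 1.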